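The source may hold more compounds than are shown below. What is called first, only, known or untested is meant among the compounds shown, and "the series" means these compounds.

Compound 1 `COc1cc(-c2nn(-c3cccc(NC(=O)Nc4ccc(Cl)c(Cl)c4)c3)cc2-c2ccncc2)ccc1Cl` is the starting point: in a functional assay on NCI/ADR-RES cells (Homo sapiens) for inhibition, read by sulforhodamine B assay, with a stated time of 48 h (a lower number here means a stronger inhibitor of growth, a higher number a weaker inhibitor of growth), compound 1 gives 4670 nM. Compound 2 `O=C(Nc1cccc(-n2cc(-c3ccncc3)c(-c3ccc(Cl)c(O)c3)n2)c1)Nc1ccc(Cl)c(Cl)c1` differs only by hydrogen in place of methyl on an oxygen on an aromatic ring. For compound 2 the this assay reports only a limit, > 32500 nM. The step of an at least 6.9-fold higher number from compound 1 to compound 2 (0.84 log units; beyond the scatter) is therefore read against that limit (the limit of > 32500 nM in this assay, at which 1 of the 2 values shown sits). Compound 3 `O=C(Nc1cccc(-n2cc(-c3ccncc3)c(-c3ccc(Cl)c(O)c3)n2)c1)Nc1ccc(Cl)c(C(F)(F)F)c1` keeps that change and alters one substituent: trifluoromethyl in place of chloro on an aromatic carbon. For the measured compounds named here, no measured step covers this change, so no movement beyond the scatter is expected, a step that the limit leaves unreadable from compound 2 to compound 3. Compound 3 is expected near 40000 nM, between 15000 nM and 100000 nM.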

Compound 3, concentration for total growth inhibition: 2750 nM
Compound 3: middle estimate off by 15-fold (1.16 log units), on the high side; measured number below the stated range.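

The earlier step touched only the oxygen on the aromatic ring, whereas this one shows that the 3,4-dichlorophenyl group also counts: trifluoromethyl in place of chloro gives an at least 11-fold lower number from compound 2 to compound 3 (1.07 log units; beyond the scatter). Keeping the hydrogen on that oxygen therefore does not by itself rule out a measured number in this assay. Compound 2 has only a limit, so this step is a minimum and its true size stays unknown: the limit of > 32500 nM in this assay, at which 1 of the 3 values shown sits.

Still open, as far as these compounds go, is whether trifluoromethyl brings a similar step when the methyl stays on the oxygen. Also open, from the compounds shown here alone, is how another group at this place, such as an amine or a nitrile, would compare.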